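Extending the urea nitrogen: from compound 2 to compound 4

The source may report more compounds than this note shows. Statements on the series, on what has been measured and on what is new or still open speak of the compounds shown alone.

Of the compounds shown here, three sharing one core have been tested in a functional assay on A549 cells (Homo sapiens) for antiproliferative activity, read by MTT assay; a higher number here means a weaker inhibitor, a lower number a stronger inhibitor. Compound 1 `COc1cc2c(Oc3ccc(NC(=O)Nc4cccc(C)c4)cc3)ccnc2cc1OCCCCCCC(=O)NO` gives 2010 nM. Compound 2 `COc1cc2c(Oc3ccc(NC(=O)Nc4ccccc4C(F)(F)F)cc3)ccnc2cc1OCCCCCCC(=O)NO` gives 5280 nM, the highest of the three numbers, and compound 3 `COc1cc2c(Oc3ccc(NC(=O)Nc4ccc(Cl)c(C(F)(F)F)c4)cc3)ccnc2cc1OCCCCCCC(=O)NO` gives 5020 nM. The step of a 1.1-fold lower number from compound 2 to compound 3 (0.02 log units; within the scatter) lies within the scatter, whereas a 2.6-fold higher number from compound 1 to compound 2 (0.42 log units; beyond the scatter) is a modest step beyond it.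

Compound 4 `COc1cc2c(Oc3ccc(NC(=O)NNC(=O)c4cccc(C)c4)cc3)ccnc2cc1OCCCCCCC(=O)NO` is not yet measured. It differs from compound 2 by ((3-methylphenyl)carbonyl)amino in place of 2-(trifluoromethyl)phenyl on an amide-type nitrogen. Among the compounds with values here, the only measured step that touches this change is a 2.6-fold higher number from compound 1 to compound 2 (0.42 log units; beyond the scatter), which shows that the 3-methylphenyl group in compound 1 is associated with the lower of the two numbers. Within the data shown here, no measured step covers the entry of the carbonylamino unit itself, so that part of the change is unanchored by data.

Compound 4 is therefore expected to give 3500 nM, within a range of 1000 nM to 12000 nM. The expected step of a 1.5-fold lower number from compound 2 to compound 4 (0.18 log units; within the scatter) is estimated as small and uncertain in direction.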

Compound 4, half-maximal inhibitory concentration: 8190 nM
Estimate against measurement, compound 4: 2.3-fold (0.37 log units) below, within the range that was stated.
By their numbers in this assay, from the lowest: compound 1; then compounds 3, 2 and 4 (each within the scatter of the next).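

In this assay, ((3-methylphenyl)carbonyl)amino on the amide-type nitrogen cannot be told apart from either trifluoromethyl-bearing phenyl group: a 1.6-fold higher number from compound 2 to compound 4 (0.19 log units; within the scatter) and a 1.6-fold higher number from compound 3 to compound 4 (0.21 log units; within the scatter) both stay within the scatter. Against the directly attached 3-methylphenyl group the same replacement is a modest step beyond the scatter, a 4.1-fold higher number from compound 1 to compound 4 (0.61 log units; beyond the scatter), so keeping the 3-methylphenyl ring while inserting a carbonylamino unit does not retain the lower number of the first compound. No measured evidence is available to explain this result.

From the compounds shown here alone, it remains open whether this step comes from the carbonylamino unit alone or depends on the ring it carries. An acetylamino group, which has no ring, or a ((2-(trifluoromethyl)phenyl)carbonyl)amino group at this nitrogen would bear on that question.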